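Swapping Bromo for Methyl in a Growth Inhibitor

The source may report more compounds than this note shows. Statements on the series, on what has been measured and on what is new or still open speak of the compounds shown alone.

Among the measured compounds shown here, in a functional assay on OVCAR-3 cells (Homo sapiens) for inhibition, read by sulforhodamine B assay, with a stated time of 48 h (a higher number here means a weaker inhibitor of growth, a lower number a stronger inhibitor of growth), compound 2 `CC(C)(C)NCc1c(C(=O)O)nn(-c2ccc(Cl)cc2)c1-c1ccc(Br)cc1` gives 513000 nM, the higher of the two numbers so far, while compound 1 `CC(C)(C)NCc1c(C(=O)O)nn(-c2ccc(Cl)cc2)c1-c1ccc(F)cc1` gives 116000 nM. Compound 3 `Cc1ccc(-c2c(CNC(C)(C)C)c(C(=O)O)nn2-c2ccc(Cl)cc2)cc1` differs from compound 2 at one spot: methyl in place of bromo on an aromatic carbon. For the measured compounds named here, only one measured step bears on this, a modest swap at that carbon, a 4.4-fold higher number from compound 1 to compound 2 (0.65 log units; beyond the scatter). A single step cannot show where methyl will fall, so only a moderate move in this assay seems reasonable. The expected change is a 2.1-fold lower number from compound 2 to compound 3 (0.31 log units; beyond the scatter), toward a lower number. Compound 3 is estimated at 250000 nM, with a range from 80000 nM to 700000 nM.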

Compound 3, concentration for 50% growth inhibition: > 629000 nM
Compound 3 was reported as a limit; the forecaster's own chance of this, stated with the estimate: 10%; at least 2.5-fold (0.40 log units) between middle value and limit.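

Compound 3 is reported in this assay only as a limit, not as a number: the limit of > 629000 nM in this assay, at which 1 of the 3 values shown sits. Methyl in place of bromo gives an at least 1.2-fold higher number from compound 2 to compound 3 (0.08 log units; that floor lies within the scatter), so this floor alone cannot separate the 4-methylphenyl group from the 4-bromophenyl group. Methyl in place of fluoro gives an at least 5.4-fold higher number from compound 1 to compound 3 (0.73 log units; beyond the scatter), so fluoro keeps the lowest number of the three groups at this position.

From the compounds shown here alone, how far the true value of compound 3 lies past its limit stays open. Going by these compounds, whether an amine or a methoxy group here would give a lower number than fluoro also stays open.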